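The source may hold more compounds than are shown below. What is called first, only, known or untested is meant among the compounds shown, and "the series" means these compounds.

Measured in an assay on isolated protein for inhibition of tyrosine-protein phosphatase non-receptor type 13 (Homo sapiens), read by spectrophotometry; a lower number here means a stronger inhibitor, a higher number a weaker inhibitor:
- compound 1 `Oc1c(-c2ccccc2)cccc1C(O)(C(F)(F)F)C(F)(F)F` gives 449000 nM
- compound 2 `Cc1ccc(S(=O)(=O)NNC(=O)COc2ccc3cc(C(O)(C(F)(F)F)C(F)(F)F)c(O)cc3c2)cc1` gives 14900 nM
- compound 3 `O=C(COc1ccc2cc(C(O)(C(F)(F)F)C(F)(F)F)c(O)cc2c1)N(c1ccccc1)c1ccccc1` gives 12400 nM

Among these three numbers compound 2 stands second highest. Its nearest neighbour is compound 3, whose value is within the scatter of repeated measurements, so the two cannot be told apart on potency. Compound 1 sits far away with a much higher number, beyond the scatter, so compound 1 is clearly the weaker inhibitor of the pair.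

Compound 4 `O=C(COc1ccc2cc(C(O)(C(F)(F)F)C(F)(F)F)c(O)cc2c1)Nc1ccc(-c2ccccc2)cc1` is the compound not yet measured. It keeps the shared core of compound 2 and changes only one part: 4-phenylphenyl in place of ((4-methylphenyl)sulfonyl)amino on an amide-type nitrogen. Among the measured compounds shown here, no measured pair in this set shows exactly this kind of swap, so there is no directly comparable step to lean on. What the set does show is that compound 2 and compound 3, two different groups on the same amide-type nitrogen, land within the scatter of each other, which argues against a large shift in either direction.

Given that, compound 4 is expected to land close to compound 2, with the step from compound 2 to compound 4 estimated at a 1.7-fold lower number from compound 2 to compound 4 (0.22 log units; within the scatter), lying within the usual scatter. For compound 4 the estimate in this assay is 9000 nM, with a range from 3000 nM to 30000 nM.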

Compound 4, half-maximal inhibitory concentration: 2800 nM
For compound 4 the middle estimate is 3.2-fold (0.51 log units) above the measured one, and the stated range ends above it.
By their numbers in this assay, from the lowest: compound 4; then compounds 3 and 2 (each within the scatter of the next); then compound 1.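

In this assay, putting 4-phenylphenyl in place of ((4-methylphenyl)sulfonyl)amino on the amide-type nitrogen gives a 5.3-fold lower number from compound 2 to compound 4 (0.73 log units; beyond the scatter), a shift that the earlier pair could not reveal, since compound 2 at 14900 nM and compound 3 at 12400 nM lie within the scatter of each other. So the group on this nitrogen can change the result by more than the scatter, and here the all-carbon biaryl group goes with the stronger inhibition. The swap alters several things at once, taking away the sulfonyl oxygens and a hydrogen-bond donor while adding a second aromatic ring of carbon only, and no supporting measurement is available to say which of these matters.

The compounds shown leave open whether both rings of 4-phenylphenyl are needed, since a plain phenyl on this nitrogen would test that directly. From the compounds shown here alone, it also remains open how the number would respond to a carboxylic acid or an amine carried on the 4-phenylphenyl group, or to a longer carbon chain on the same nitrogen.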